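The source may hold more compounds than are shown below. What is called first, only, known or untested is meant among the compounds shown, and "the series" means these compounds.

In a functional assay on K562 cells (Homo sapiens) for inhibition, read by trypan blue exclusion, with a stated time of 72 h (on this read-out lower numbers stand for stronger inhibition and higher numbers for weaker inhibition), the three measured compounds give the following:

- compound 1 `Cn1c(=O)c(S(=O)(=O)c2ccc(F)cc2F)cc2cnc(Nc3ccc4cccc(O)c4n3)nc21`: 5000 nM
- compound 2 `Cn1c(=O)c(S(=O)(=O)c2ccc(F)cc2F)cc2cnc(Nc3ccccn3)nc21`: 35000 nM
- compound 3 `Cn1c(=O)c(S(=O)(=O)c2ccc(F)cc2F)cc2cnc(Nc3ccc4c(c3)CC(=O)N4)nc21`: 15000 nM

Compound 3 stands second highest of the three numbers in this assay: compound 1 sits lower by a 3.0-fold higher number from compound 1 to compound 3 (0.48 log units; beyond the scatter), and compound 2 higher by a 2.3-fold lower number from compound 2 to compound 3 (0.37 log units; beyond the scatter). Compound 4 `Cn1c(=O)c(S(=O)(=O)c2ccc(F)cc2F)cc2cnc(NCc3ccc4[nH]ccc4c3)nc21` differs from compound 3 in one place: a group of 10 heavy atoms (9 carbon, 1 nitrogen; one five-membered aromatic ring with 1 hetero atom, one six-membered aromatic ring of carbon only) in place of a group of 10 heavy atoms (8 carbon, 1 nitrogen, 1 oxygen; one five-membered non-aromatic ring with 1 hetero atom, one six-membered aromatic ring of carbon only), on a nitrogen on an aromatic ring. The two steps that bear on this change are a 3.0-fold higher number from compound 1 to compound 3 (0.48 log units; beyond the scatter) and a 2.3-fold lower number from compound 2 to compound 3 (0.37 log units; beyond the scatter), both modest, both on the same nitrogen, and both showing that swapping the group there moves the number only moderately. Going by the values given here, no measured step matches the entering group itself, so a similar, modest change is expected here, on the weaker side, giving an estimated step of a 1.5-fold higher number from compound 3 to compound 4 (0.17 log units; within the scatter). Compound 4 is therefore estimated at 22000 nM in this assay, with a range from 7000 nM to 70000 nM.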

Compound 4, half-maximal inhibitory concentration: 75000 nM
Beside the measured number, compound 4's estimate is 3.4-fold (0.53 log units) below it, outside the stated range (above it).
By their numbers in this assay, from the lowest: compound 1; then compound 3; then compound 2; then compound 4.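

Going by these compounds alone, compound 4 gives the weakest inhibition of the four, with a 5.0-fold higher number from compound 3 to compound 4 (0.70 log units; beyond the scatter) and a 2.1-fold higher number from compound 2 to compound 4 (0.33 log units; beyond the scatter) and also a 15-fold higher number from compound 1 to compound 4 (1.18 log units; beyond the scatter), the widest gap yet at this nitrogen. (1H-indol-5-yl)methyl is also the only group here that carries a methyl link, but the ring changes with it, so the two changes cannot be separated. Nothing available explains the loss.

As far as these compounds go, whether a plain benzyl group would behave the same remains open, as does the effect of a 2-aminoethyl chain at this nitrogen.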